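Compound 3 to compound 4: 2-fluorobenzyl to 4-chlorobenzyl

The source may report more compounds than this note shows. Statements on the series, on what has been measured and on what is new or still open speak of the compounds shown alone.

In a functional assay on a cell-free system (plasma, Oryctolagus cuniculus) for inhibition, with stated times of 5 min, 1 min and 6 min (a higher number here means a weaker inhibitor, a lower number a stronger inhibitor), compound 1 `CCOC(=O)c1[nH]c(-c2cccc(C#N)c2)nc1C` gives > 30000 nM, which is a limit of the assay and not a number. Two compounds with a group on the aromatic nitrogen give numbers: compound 2 `CCOC(=O)c1c(C)nc(-c2cccc(C#N)c2)n1OCc1ccncc1` gives 6200 nM and compound 3 `CCOC(=O)c1c(C)nc(-c2cccc(C#N)c2)n1OCc1ccccc1F` gives 8990 nM. These two values lie within the scatter of each other, so compound 3 stands level with compound 2 on the present data.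

The next compound is compound 4 `CCOC(=O)c1c(C)nc(-c2cccc(C#N)c2)n1OCc1ccc(Cl)cc1`, which has 4-chlorophenyl in place of 2-fluorophenyl on a saturated chain carbon bound to an oxygen on an aromatic ring. Read one bond further out, this is (4-chlorobenzyl)oxy replacing (2-fluorobenzyl)oxy.

Two measured steps add a group on the aromatic nitrogen: an at least 4.8-fold lower number from compound 1 to compound 2 (0.68 log units; beyond the scatter) and an at least 3.3-fold lower number from compound 1 to compound 3 (0.52 log units; beyond the scatter). Both lie beyond the scatter, but compound 4 retains a group at that place, so they say little about this exchange. Among the compounds with values here, the closest guide is the only exchange measured at the changing place, a 1.5-fold higher number from compound 2 to compound 3 (0.16 log units; within the scatter), which stays within the scatter.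

No step beyond the scatter is therefore expected in this assay. The expected step is a 1.5-fold lower number from compound 3 to compound 4 (0.18 log units; within the scatter). Compound 4 is estimated at 6000 nM, with an expected range from 2000 nM to 18000 nM.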

Compound 4, half-maximal inhibitory concentration: 6830 nM
Compound 4: the middle estimate sits 1.1-fold (0.06 log units) below what was measured; the range from low to high includes it.
By their numbers in this assay, from the lowest: compounds 2, 4 and 3 (each within the scatter of the next). At a limit, above all of these: compound 1.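

In this assay, 4-chlorophenyl on the saturated chain carbon bound to an oxygen on an aromatic ring gives a 1.3-fold lower number from compound 3 to compound 4 (0.12 log units; within the scatter) and a 1.1-fold higher number from compound 2 to compound 4 (0.04 log units; within the scatter), both within the scatter, so compounds 2, 3 and 4 read as level across a chlorine-bearing, a fluorine-bearing and a pyridine ring at this place. Because compound 4 differs from compound 3 in both the halogen and the name-position of that halogen, the two changes cannot be read apart here, and the level result holds only for their sum. The step of an at least 4.3-fold lower number from compound 1 to compound 4 (0.64 log units; beyond the scatter) adds (4-chlorobenzyl)oxy as a third group on the aromatic nitrogen that lies beyond the scatter from hydrogen. Compound 1 stands at a limit of the assay and not at a number, so that step is a bound only: the limit of > 30000 nM in this assay, at which 1 of the 4 values shown sits.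

On these data alone, whether any group at this place separates from the others stays open, since compounds 2, 3 and 4 all lie within the scatter of each other. A 2-phenylethyl chain in place of benzyl, or a benzyl group carrying an amine or a carboxylic acid, would test how far this flat reading extends.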